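Removing the nitrile from compound 1: an expected drop

The compounds below may be only part of what the source reports. "The series", "measured", "known", "first", "only" and "open" are said of these compounds alone.

This account follows a single change made to compound 1 `N#Cc1ccccc1-c1nc2cccnc2o1` and what it is expected to do in a functional assay on the whole organism for inhibition, with Rattus norvegicus as the target, at a dose of 30 mg/kg; on this read-out higher numbers stand for more inhibition at the one dose given (going by the name of the read-out) and lower numbers for less inhibition. Compound 1 gives 61% in this assay, the highest of the three numbers recorded. Compound 2 `Fc1cccc(F)c1-c1nc2cccnc2o1` gives 50% in this assay, a value below that of compound 1 by more than the scatter. Compound 3 `Brc1cccc(-c2nc3ncccc3o2)c1` gives 23% in this assay, the lowest of the three and far below compound 1.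

Compound 4 `c1ccc(-c2nc3cccnc3o2)cc1` is the untested compound. It differs from compound 1 as follows: hydrogen in place of cyano on an aromatic carbon. Compound 4 keeps the shared core and the six-membered aromatic ring of carbon only, but carries no group at all on that ring. Among the measured compounds, compound 3 shows that a weaker read-out is possible when the cyano of compound 1 is absent, which makes a downward step in this assay for compound 4 expected, beyond the scatter, as a number 26 percentage points lower from compound 1 to compound 4 (beyond the scatter). Compound 4 is therefore estimated to give 35% in this assay, with a range from 15% to 55%.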

Compound 4, a percentage reported as inhibition, in the whole organism at one dose (the size of the read-out at that dose, not a potency): 55%
Beside the measured number, compound 4's estimate is 20 percentage points below it; measured number inside the range.
By their numbers in this assay, from the lowest: compound 3; then compounds 2, 4 and 1 (each within the scatter of the next, the first and the last beyond it).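

Putting hydrogen in place of cyano on an aromatic carbon gives, in this assay, a number 6 percentage points lower from compound 1 to compound 4 (within the scatter), so at this one dose the read-out does not depend measurably on the cyano at this place. Among these compounds, neither of the earlier compounds differs from compound 1 in one place only, so this is the first direct reading of the cyano by itself, and it shows that losing the cyano alone does not bring a large step. Nothing measured here says why this step stays within the scatter.

On these data alone, whether another group at this place, such as an amine, a carboxylic acid or a longer chain, would give a step beyond the scatter remains open. The read-out also stands at a single dose, so it leaves open whether compound 1 and compound 4 would stay within the scatter of each other at other doses.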